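The source may report more compounds than this note shows. Statements on the series, on what has been measured and on what is new or still open speak of the compounds shown alone.

Working notes on the series. Compound 1 `COc1cc(C(=O)/C=C/c2cn(C)c3ccccc23)cc(N)c1OC`, compound 2 `COc1cc(C(=O)/C(C)=C/c2c[nH]c3ccccc23)cc([Se]C)c1OC` and compound 3 `COc1ccc2c(/C=C(\C)C(=O)c3cc(OC)c(OC)c([Se]C)c3)c[nH]c2c1` share one core and have been run in a functional assay on MCF7 cells (Homo sapiens) for antiproliferative activity, read by MTT assay, with a stated time of 48 h; on this read-out lower numbers stand for stronger inhibition and higher numbers for weaker inhibition. In this assay compound 1 gives 631 nM, compound 2 gives 59 nM and compound 3 gives 35 nM. Among these three numbers compound 2 stands second highest: the step of a 1.7-fold lower number from compound 2 to compound 3 (0.23 log units; within the scatter) is the nearest, while compound 1 is the furthest, with a number that lies beyond the scatter from compound 2.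

Compound 4 `COc1cc(C(=O)/C(C)=C/c2cn(C)c3ccccc23)cc([Se]C)c1OC` differs from compound 2 by methyl in place of hydrogen on an aromatic nitrogen. Going by the values given here, no measured step probes this change directly. Among the compounds with values here, the only single-place step in hand, a 1.7-fold lower number from compound 2 to compound 3 (0.23 log units; within the scatter), concerns a methoxy on an aromatic carbon and is within the scatter. Compound 1 carries a methyl on the same aromatic nitrogen, but it differs from compound 2 in other places too, so its value alone does not isolate the change. With nothing to point either way, no step beyond the scatter is expected.

Compound 4 is therefore expected to give about 70 nM in this assay, with a range from 25 nM to 200 nM. The expected step is a 1.2-fold higher number from compound 2 to compound 4 (0.07 log units; within the scatter).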

Compound 4, half-maximal inhibitory concentration: 77 nM
Compound 4: middle estimate off by 1.1-fold (0.04 log units), on the low side; the range from low to high includes it.
By their numbers in this assay, from the lowest: compounds 3, 2 and 4 (each within the scatter of the next, the first and the last beyond it); then compound 1.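

In this assay, going by these compounds alone, methyl in place of hydrogen on the aromatic nitrogen of the five-membered ring gives a 1.3-fold higher number from compound 2 to compound 4 (0.12 log units; within the scatter) as the first direct reading of this position. With the rest of compound 2 held fixed, the hydrogen on this nitrogen can therefore be replaced by methyl without a change beyond the scatter. No supporting data on the compounds shown bear on this small step.

Going by these compounds, it remains open whether a larger group on this nitrogen, such as an ethyl, a longer chain or a chain ending in a carboxylic acid or an amine, would also stay within the scatter of compound 2. Also open, on these data alone, is whether the methyl would give a similar step in compound 3, which carries a methoxy on an aromatic carbon.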